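Fluoro for trifluoromethoxy on a trimethoxyphenyl triazole

This account rests on a few compounds, and the source may have more. Where it says the series, first, only, none or still open, it means among the compounds named here.

Measured compounds:
compound 1 `COc1cc(-n2ncnc2-c2ccc(OC(F)(F)F)cc2)cc(OC)c1OC`, > 10000 nM
compound 2 `CCOc1cccc(-c2ncnn2-c2cc(OC)c(OC)c(OC)c2)c1`, > 10000 nM
compound 3 `COc1cc(-c2ncnn2-c2cccc([N+](=O)[O-])c2)cc(OC)c1OC`, > 10000 nM

All three measurements come from a functional assay on Jurkat cells (Homo sapiens) for antiproliferative activity, read by MTT assay, with a stated time of 72 h; on this read-out lower numbers stand for stronger inhibition and higher numbers for weaker inhibition. The value for compound 1 is a limit of the assay, not a number. The same holds for compound 2, whose value is also a limit. Compound 3 likewise gives only a limit. So compound 1 stands at the same limit as every other compound shown, and no ordering among them can be drawn: the limit of > 10000 nM in this assay, at which 3 of the 3 values shown sit.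

Compound 4 `COc1cc(-n2ncnc2-c2ccc(F)cc2)cc(OC)c1OC` differs from compound 1 in one place: fluoro in place of trifluoromethoxy on an aromatic carbon. Among the compounds with values here, no measured pair shows what such a change does here, so there is no measured step to lean on. Since every shown value sits at the limit, a large drop in the number for compound 4 is not expected; the most likely outcome is that compound 4 also reports only a limit. The expected step from compound 1 to compound 4 is a step that the limit leaves unreadable from compound 1 to compound 4, which is no step beyond the scatter. Compound 4 is estimated at 15000 nM, in a range from 3000 nM to 60000 nM.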

Compound 4, half-maximal inhibitory concentration: > 10000 nM
Compound 4 ended at the assay's limit; the forecaster's own chance of this, stated with the estimate: 75%; the middle value does not contradict the limit.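

Compound 1 and compound 4 both end at a limit rather than a number, so fluoro in place of trifluoromethoxy gives no readable step: the limit of > 10000 nM in this assay, at which 4 of the 4 values shown sit.

The compounds shown leave open whether any change to the shared core gives a readable number, and how compound 1, compound 2, compound 3 and compound 4 truly rank.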